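Extending the Amine Side Chain of Compound 1

A few compounds are considered here, and "the series" means these few. Any claim that something is new, unique, unknown or untested is made for them only; others in the source may bear on it.

Compound 1 `CN(C)CCNc1nc(-c2ccc(NC(=O)Nc3ccc(F)cc3)cc2)nc2ccsc12` carries a urea-linked 4-fluorophenyl group and a short amine-bearing chain on the shared core. In a functional assay on MDA-MB-231 cells (Homo sapiens) for cytotoxicity, read by MTT assay, with a stated time of 72 h (on this read-out higher numbers stand for weaker inhibition and lower numbers for stronger inhibition), compound 1 gives 540 nM, the lowest number among the three measured, although compound 2 lies within the scatter of it. Compound 2 `CN(C)CCNc1nc(-c2ccc(NC(=O)Nc3ccccc3Cl)cc2)nc2ccsc12` differs only on the urea, and in this assay compound 2 gives 550 nM, the step being a 1.0-fold higher number from compound 1 to compound 2 (0.01 log units; within the scatter). Compound 3 `CN(C)CCNc1nc(-c2ccc(NC(=O)Nc3ccc(Cl)cc3Cl)cc2)nc2ccsc12`, bearing a 2,4-dichlorophenyl group, gives 2450 nM in this assay, a change of a 4.5-fold higher number from compound 1 to compound 3 (0.66 log units; beyond the scatter) and, counted from its closer neighbour, a 4.5-fold higher number from compound 2 to compound 3 (0.65 log units; beyond the scatter). Compound 4 `CCN(CC)CCCNc1nc(-c2ccc(NC(=O)Nc3ccc(F)cc3)cc2)nc2ccsc12` leaves the urea untouched and instead alters the amine chain: (diethylamino)methyl in place of dimethylamino on a saturated chain carbon, two bonds along the chain from a nitrogen on an aromatic ring. For the measured compounds named here, none of the measured steps touches this chain; all three vary the urea group alone, so they offer no guide to the direction of the change. Going by the values given here, with no comparable step to draw on, the expectation for compound 4 in this assay is a step of a 1.1-fold higher number from compound 1 to compound 4 (0.05 log units; within the scatter), within the scatter. Compound 4 is therefore estimated at 600 nM, with a range from 250 nM to 1500 nM.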

Compound 4, half-maximal inhibitory concentration: 530 nM
Beside the measured number, compound 4's estimate is 1.1-fold (0.05 log units) above it; low and high end bracket the measured number.
By their numbers in this assay, from the lowest: compounds 4, 1 and 2 (each within the scatter of the next); then compound 3.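

Replacing the 2-(dimethylamino)ethyl chain of compound 1 with the 3-(diethylamino)propyl chain gives, in this assay, a 1.0-fold lower number from compound 1 to compound 4 (0.01 log units; within the scatter). For the compounds shown here, this is the first look at the amine chain: a larger group, with 6 heavy atoms entering where 3 leave, fits at this position without a shift that can be told from the scatter, whereas the urea change in a 4.5-fold higher number from compound 2 to compound 3 (0.65 log units; beyond the scatter) went beyond it. No measurement shown here explains this tolerance.

The step alters the chain length and the groups on the nitrogen at once, so the two changes remain unseparated. Also open, from the compounds shown here alone, is whether a ring amine such as morpholine or piperidine at the chain end, or a carboxylic acid there, would leave the number equally unmoved.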